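The compounds below may be only part of what the source reports. "The series", "measured", "known", "first", "only" and "open" are said of these compounds alone.

Measured compounds:
compound 1 `CC(C)NC(=O)CC(c1ccc(-c2ccc3cccc(F)c3c2)[nH]c1=O)C(C)C` — 15 nM
compound 2 `CC(C)C(Cc1ncc[nH]1)c1ccc(-c2ccc3cccc(F)c3c2)[nH]c1=O` — 76 nM
compound 3 `CC(C)C(/C=C1\CCNC1=O)c1ccc(-c2ccc3cccc(F)c3c2)[nH]c1=O` — 8.7 nM

In a functional assay on CHO cells for antagonist activity at prostaglandin E2 receptor EP3 subtype (Homo sapiens), read by cAMP accumulation (a lower number here means a stronger inhibitor, a higher number a weaker inhibitor), compound 3 gives the lowest of the three numbers, though its gap to compound 1, a 1.7-fold lower number from compound 1 to compound 3 (0.24 log units; within the scatter), lies within the scatter, while an 8.7-fold lower number from compound 2 to compound 3 (0.94 log units; beyond the scatter) is beyond it. Compound 4 `CC(C)C(c1noc(=O)[nH]1)c1ccc(-c2ccc3cccc(F)c3c2)[nH]c1=O` differs from compound 3 by a group of 6 heavy atoms (2 carbon, 2 nitrogen, 2 oxygen; one five-membered aromatic ring with 3 hetero atoms) in place of a group of 7 heavy atoms (5 carbon, 1 nitrogen, 1 oxygen; one five-membered non-aromatic ring with 1 hetero atom), on a saturated chain carbon bound to an aromatic carbon and a saturated chain carbon. For the measured compounds named here, two steps bear on this. The imidazole-bearing compound 2 sat above compound 1, a 5.1-fold higher number from compound 1 to compound 2 (0.70 log units; beyond the scatter), and above compound 3, an 8.7-fold lower number from compound 2 to compound 3 (0.94 log units; beyond the scatter); an aromatic five-membered ring with hetero atoms now re-enters in place of the non-aromatic ring, so a modest rise in this assay is expected, smaller than seen for compound 2. Compound 4 is therefore estimated at 35 nM, between 12 nM and 110 nM, a step of a 4.0-fold higher number from compound 3 to compound 4 (0.60 log units; beyond the scatter) expected.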

Compound 4, half-maximal inhibitory concentration: 41 nM
Beside the measured number, compound 4's estimate is 1.2-fold (0.07 log units) below it; low and high end bracket the measured number.
By their numbers in this assay, from the lowest: compounds 3 and 1 (each within the scatter of the next); then compounds 4 and 2 (each within the scatter of the next).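

In this assay, the five-membered aromatic ring with 3 hetero atoms on this saturated chain carbon gives a higher number than either the non-aromatic ring (a 4.7-fold higher number from compound 3 to compound 4 (0.67 log units; beyond the scatter)) or the open isopropylcarbamoyl group (a 2.7-fold higher number from compound 1 to compound 4 (0.44 log units; beyond the scatter)). Against the imidazol-2-yl group of compound 2 the change stays within the scatter (a 1.9-fold lower number from compound 2 to compound 4 (0.27 log units; within the scatter)), so these two aromatic rings are not told apart here. No evidence at hand explains this rise. The compounds shown leave open whether a carboxylic acid or a primary amine on this carbon would match the aromatic rings or the amide-bearing groups.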